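The compounds below may be only part of what the source reports. "The series", "measured", "known", "first", "only" and "open" are said of these compounds alone.

Measured compounds:
Compound 1 `Oc1ccc(CNc2cc(C(F)(F)F)cc3[nH]ncc23)cc1` gives 2550 nM in an assay for inhibition of Tryptophan 2,3-dioxygenase (Homo sapiens), with stated times of 10 min and 60 min; on this read-out lower numbers stand for stronger inhibition and higher numbers for weaker inhibition.
Compound 2 `O=C(O)c1cccc(CNc2cc(C(F)(F)F)cc3[nH]ncc23)c1` gives 1690 nM in this assay.
Compound 3 `OC1CCCC(Nc2cccc(CNc3cc(C(F)(F)F)cc4[nH]ncc34)c2)C1` gives only a limit of the assay, > 100000 nM, in this assay.

Compound 3 thus stands at the edge of what this assay can report: its value is not a number but a limit, (the limit of > 100000 nM in this assay, at which 1 of the 3 values shown sits). Going by the values given here, the only measured step that reaches compound 3 is an at least 59-fold higher number from compound 2 to compound 3 (1.77 log units; beyond the scatter), where the small carboxy group of compound 2 was exchanged for the larger (3-hydroxycyclohexyl)amino group and inhibition fell out of the measurable range.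

Compound 4 `Nc1cccc(CNc2cc(C(F)(F)F)cc3[nH]ncc23)c1` reverses part of that change: hydrogen in place of 3-hydroxycyclohexyl on a nitrogen on an aromatic ring. What remains at that position is a bare amino group, a small substituent comparable in size to the hydroxy of compound 1 and the carboxy of compound 2. Both of those compounds were measured within the range of this assay, so the step is expected to run in the direction of stronger inhibition, and by a large margin, since it starts from a limit. Compound 4 is expected to give 3000 nM, between 800 nM and 20000 nM. This estimate means an at least 33-fold lower number from compound 3 to compound 4 (1.52 log units; beyond the scatter), resting on compound 2 with 1690 nM and compound 1 with 2550 nM.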

Compound 4, half-maximal inhibitory concentration: 2510 nM
Compound 4: the middle estimate sits 1.2-fold (0.08 log units) above what was measured, within the range that was stated.
By their numbers in this assay, from the lowest: compounds 2, 4 and 1 (each within the scatter of the next). At a limit, above all of these: compound 3.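

In this assay, taking the 3-hydroxycyclohexyl off the nitrogen gives an at least 39-fold lower number from compound 3 to compound 4 (1.60 log units; beyond the scatter), so the loss goes with the 3-hydroxycyclohexyl and not with the nitrogen on the aromatic ring, which remains as a bare amino group. Amino in place of carboxy gives a 1.5-fold higher number from compound 2 to compound 4 (0.17 log units; within the scatter), and 3-aminophenyl in place of 4-hydroxyphenyl gives a 1.0-fold lower number from compound 1 to compound 4 (0.01 log units; within the scatter), so neither exchange moves the number beyond the scatter, and these three compounds read alike whether the ring carries carboxy, amino or hydroxy. Compound 3 is reported only as a limit, so the full size of its step to the amino compound stays unknown: the limit of > 100000 nM in this assay, at which 1 of the 4 values shown sits.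

The compounds shown leave open whether a methyl group or a cyclohexyl without the hydroxy on that nitrogen would keep the number of the amino compound or lose it as the 3-hydroxycyclohexyl does. They also leave open how the ring would read with a methoxy group or a nitrile in place of the amino group.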